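Replacing Ethoxycarbonyl with Phenyl in Compound 1

The source may report more compounds than this note shows. Statements on the series, on what has been measured and on what is new or still open speak of the compounds shown alone.

In an ADME assay on HeLa cells (Homo sapiens) for cytotoxicity, read by crystal violet staining, with a stated time of 72 h (a higher number here means that more compound is tolerated, a lower number that less compound is tolerated), compound 1 `CCOC(=O)c1cc(CCCOc2c(C)cc(-c3noc(C(F)(F)F)n3)cc2C)on1` gives 17200 nM, the lower of the two numbers available. Compound 2 `CCOC(=O)c1cc(CCCOc2ccc(-c3noc(C(F)(F)F)n3)cc2C)on1` gives 35100 nM. Compound 3 `CCOC(=O)c1cc(CCCOc2ccc(-c3noc(C(F)(F)F)n3)cc2[N+](=O)[O-])on1` reads > 100000 nM, which is a limit of the assay and not a number. The unmeasured compound 4 `Cc1cc(-c2noc(C(F)(F)F)n2)cc(C)c1OCCCc1cc(-c2ccccc2)no1` keeps the core of compound 1 and carries phenyl in place of ethoxycarbonyl on an aromatic carbon. Two measured steps offer indirect guidance. Hydrogen in place of methyl gave a 2.0-fold higher number from compound 1 to compound 2 (0.31 log units; beyond the scatter), a modest change. Nitro in place of methyl gave an at least 2.8-fold higher number from compound 2 to compound 3 (0.45 log units; beyond the scatter), a change that is at least modest. Neither step replaces ethoxycarbonyl, so neither measures this exchange directly, and they suggest only the size that a single change can reach in this assay. No step beyond the scatter is expected, and a firm direction cannot be assigned. The estimated outcome is a 1.3-fold higher number from compound 1 to compound 4 (0.11 log units; within the scatter). For compound 4 the expected value is 22000 nM, with an estimated range from 7000 nM to 70000 nM.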

Compound 4, half-maximal cytotoxic concentration: > 100000 nM
Compound 4: no number, only a limit (the forecaster's own chance of this, stated with the estimate: 20%); at least 4.5-fold (0.65 log units) between middle value and limit.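

Until now, every compound shown carried ethoxycarbonyl on this aromatic carbon, so the earlier steps said nothing about this position. Compound 4 shows that the group next to the ring nitrogen also moves the result in this assay: exchanging ethoxycarbonyl for phenyl gives an at least 5.8-fold higher number from compound 1 to compound 4 (0.76 log units; beyond the scatter). Compound 4 gives only a limit and not a number, so this step has a lower bound but no known full size: the limit of > 100000 nM in this assay, at which 2 of the 4 values shown sit.

Compound 3 and compound 4 cannot be placed in order, as each gives only a limit. As far as these compounds go, it also remains open whether the change comes from losing ethoxycarbonyl or from gaining phenyl, and what a carboxylic acid, an amine or a smaller alkyl group on this carbon would give.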